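Compound 3 to compound 4: changing the benzyl group

The source may hold more compounds than are shown below. What is called first, only, known or untested is meant among the compounds shown, and "the series" means these compounds.

Within the data shown here, in a functional assay on a cell-free system (plasma, Oryctolagus cuniculus) for inhibition, with stated times of 5 min, 1 min and 6 min (a higher number here means a weaker inhibitor, a lower number a stronger inhibitor), compound 3 `CCOC(=O)c1c(C)nc(-c2cccc(C#N)c2)n1OCc1cccc(F)c1` stands at 22400 nM and lies within the scatter of compound 1 `CCOC(=O)c1c(C)nc(-c2cccc(C#N)c2)n1O` at 17600 nM on the numbers so far. Compound 2 `CCOC(=O)COn1c(-c2cccc(C#N)c2)nc(C)c1C(=O)OCC` reads 6800 nM and stands apart from the other two, the gap being a 3.3-fold higher number from compound 2 to compound 3 (0.52 log units; beyond the scatter) in the series.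

The next structure, compound 4 `CCOC(=O)c1c(C)nc(-c2cccc(C#N)c2)n1OCc1ccc(OC)cc1` with the shared core, carries 4-methoxyphenyl in place of 3-fluorophenyl on a saturated chain carbon bound to an oxygen on an aromatic ring and the same difference, cut one bond further out, reads 3-fluorobenzyl to 4-methoxybenzyl.

Among the measured compounds shown here, no measured step makes this exact exchange. The closest evidence is a 1.3-fold higher number from compound 1 to compound 3 (0.10 log units; within the scatter) on placing 3-fluorobenzyl in place of hydrogen. The step beyond the scatter from the same starting point, a 2.6-fold lower number from compound 1 to compound 2 (0.41 log units; beyond the scatter) for (ethoxycarbonyl)methyl in place of hydrogen, involves no benzyl group and says little here. The data hold no comparison of two substituted benzyl groups, so no step beyond the scatter is expected in this assay for this change. The expected step is a 1.1-fold lower number from compound 3 to compound 4 (0.05 log units; within the scatter) with no firm direction. For compound 4 the estimated value is 20000 nM (expected range 9000 nM to 45000 nM).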

Compound 4, half-maximal inhibitory concentration: 6830 nM
Compound 4: middle estimate off by 2.9-fold (0.47 log units), on the high side; the measured number lies below the stated range.
By their numbers in this assay, from the lowest: compounds 2 and 4 (each within the scatter of the next); then compounds 1 and 3 (each within the scatter of the next).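

In this assay the choice of benzyl group on this oxygen matters: the series now holds a comparison of two substituted benzyl groups, and 4-methoxyphenyl in place of 3-fluorophenyl gives a 3.3-fold lower number from compound 3 to compound 4 (0.52 log units; beyond the scatter) on the saturated chain carbon. Measured against the free hydrogen, the two benzyl groups part, with a 1.3-fold higher number from compound 1 to compound 3 (0.10 log units; within the scatter) for 3-fluorobenzyl and a 2.6-fold lower number from compound 1 to compound 4 (0.41 log units; beyond the scatter) for 4-methoxybenzyl, so a benzyl group at this place does not by itself fix the number. The ester-bearing chain and the 4-methoxybenzyl group cannot be told apart here, with a 1.0-fold higher number from compound 2 to compound 4 (0.00 log units; within the scatter) for 4-methoxyphenyl in place of ethoxycarbonyl, so two quite different groups at this place reach the same level.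

The compounds shown do not separate the change of ring substituent from the change of its place on the ring, and the reading of plain benzyl, or of a benzyl ring carrying an amine or a carboxylic acid, stays open. No supporting data on any property of these groups bear on this result.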